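Chain-end change in an acyltransferase amide series

The source may report more compounds than this note shows. Statements on the series, on what has been measured and on what is new or still open speak of the compounds shown alone.

Compound 1 `CCCCCCCCCCC(C)(C)C(=O)Nc1c(C)c(N)c(C)c2c1OC(C)(C)C2` and compound 2 `Cc1cc(C)c(NC(=O)C(C)(C)CCCCc2ccccc2)c2c1CC(C)(C)O2` share an amide on the same core. In an assay for inhibition of acyl-CoA:cholesterol acyltransferase (Oryctolagus cuniculus), using microsomes (a higher number here means a weaker inhibitor, a lower number a stronger inhibitor), compound 1 gives 59 nM, while compound 2 gives 210 nM, the higher of the two numbers shown and beyond the scatter from compound 1. Compound 3 `Cc1cc(C)c(NC(=O)C(C)(C)CCCCCOc2ccc(Cl)cc2)c2c1CC(C)(C)O2` carries (4-chlorophenoxy)methyl in place of phenyl on a saturated chain carbon, five bonds along the chain from a carbonyl carbon. For the measured compounds named here, no measured pair shows this change, and the longer chain of compound 1 is the only hint. The expected step from compound 2 to compound 3 a 1.9-fold lower number from compound 2 to compound 3 (0.28 log units; within the scatter) is modest, toward a lower number, possibly within the scatter. Compound 3 is estimated at 110 nM in this assay, within 35 nM to 400 nM.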

Compound 3, half-maximal inhibitory concentration: 150 nM
Compound 3: the middle estimate sits 1.4-fold (0.13 log units) below what was measured; measured number inside the range.
By their numbers in this assay, from the lowest: compound 1; then compounds 3 and 2 (each within the scatter of the next).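

In this assay the change gives a 1.4-fold lower number from compound 2 to compound 3 (0.15 log units; within the scatter), so (4-chlorophenoxy)methyl is tolerated in place of phenyl at this position. The entering group has 9 heavy atoms against 6 and brings a hydrogen-bond acceptor, yet no change beyond the scatter follows. Nothing available explains this result.

From the compounds shown here alone, it remains open whether an amine or a carboxylic acid at this chain end would move the number beyond the scatter. Also open, going by these compounds, is what plain phenoxymethyl would give, which would separate the chlorine from the ether oxygen.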